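A few compounds are considered here, and "the series" means these few. Any claim that something is new, unique, unknown or untested is made for them only; others in the source may bear on it.

Measured compounds:
- compound 1, `O=[N+]([O-])c1ccccc1NC(CO)CO`, in a functional assay on BXPC-3 cells (Homo sapiens) for cytotoxicity (on this read-out higher numbers stand for weaker inhibition and lower numbers for stronger inhibition), compound 1 gives > 100000 nM, which is a limit of the assay and not a number.
- compound 2, `O=[N+]([O-])c1ccc(NC(CO)CO)c([N+](=O)[O-])c1`, in this assay compound 2 gives > 100000 nM, again a limit of the assay.

Among the measured compounds shown here, compound 2 therefore stands at the limit, where the limit of > 100000 nM in this assay, at which 2 of the 2 values shown sit, places it, and the only step among the measured compounds, a step that the two limits leave unreadable from compound 1 to compound 2, is one that the two limits leave unreadable. The move to compound 3, `O=[N+]([O-])c1cc(C(F)(F)F)ccc1NC(CO)CO`, is trifluoromethyl in place of nitro on an aromatic carbon. For the measured compounds named here, no measured step bears on this change, since the single step between compound 1 and compound 2 concerns a nitro group entering in place of hydrogen and has no readable size. Going by the values given here, with both measured compounds sitting at the limit and no informative step, there is no ground for expecting compound 3 to come out in a different place; the expected step that the limit leaves unreadable from compound 2 to compound 3 is none beyond the scatter. Compound 3 is estimated to give 150000 nM in this assay, in a range from 40000 nM to 600000 nM, most likely reported as a limit again.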

Compound 3, half-maximal inhibitory concentration: > 100000 nM
Compound 3: no number, only a limit (the forecaster's own chance of this, stated with the estimate: 80%); the middle value is on the limit's open side.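

In this assay compound 3 gives > 100000 nM, which is a limit of the assay and not a number, so its steps from compound 1 and compound 2 cannot be read. All three compounds end in the same place: the limit of > 100000 nM in this assay, at which 3 of the 3 values shown sit.

What they leave open is whether swapping hydrogen, nitro and trifluoromethyl on the shared core changes the actual potency in this assay.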